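Cyclopropyl for tert-butyl on the ring nitrogen

This account rests on a few compounds, and the source may have more. Where it says the series, first, only, none or still open, it means among the compounds named here.

The series shares one core, seen first in compound 1 `CC1CN(c2cc3c(cc2[N+](=O)[O-])c(=O)c(C(=O)O)cn3-c2ccc(F)cc2)CC(C)O1`, which carries a nitro group and a fluorophenyl on the aromatic nitrogen. In an ADME assay on Vero cells (Chlorocebus sabaeus) for cytotoxicity, read by MTT assay, with a stated time of 72 h (a lower number here means that less compound is tolerated, a higher number that more compound is tolerated), compound 1 gives 70800 nM. Compound 2 `CN1CCN(c2cc3c(cc2[N+](=O)[O-])c(=O)c(C(=O)O)cn3C(C)(C)C)CC1c1ccccc1` and compound 3 `CC(C)(C)n1cc(C(=O)O)c(=O)c2cc([N+](=O)[O-])c(N3CCN(C(=O)C4COc5ccccc5O4)CC3)cc21` belong to the same family, but for neither of them does this assay return a number: compound 2 gives "not determined" (no result reported), and compound 3 gives "not determined" (no result reported). Among the measured compounds shown here, compound 2 therefore stands without a value of its own; the only number in hand is that of compound 1.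

Compound 4 `CN1CCN(c2cc3c(cc2[N+](=O)[O-])c(=O)c(C(=O)O)cn3C2CC2)CC1c1ccccc1` differs from compound 2 in one place: cyclopropyl in place of tert-butyl on an aromatic nitrogen. For the measured compounds named here, no measured pair shows what this exchange does in this assay, so no direction can be read from the data; a step no larger than the usual scatter would be unsurprising. Compound 4 is expected to tolerate a concentration around 50000 nM, with a range from 15000 nM to 200000 nM.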

Compound 4, half-maximal cytotoxic concentration: 136000 nM
Compound 4: middle estimate off by 2.7-fold (0.43 log units), on the low side; the measured number falls inside the stated range.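

Compound 4 at 136000 nM cannot be set against compound 2, which has no single number, so no step can be read between them. On these data alone, what cyclopropyl in place of tert-butyl does in this assay stays open. No supporting evidence bears on this result.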